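Aryl swap on the shared core: thiophen-2-yl analogue

A few compounds are considered here, and "the series" means these few. Any claim that something is new, unique, unknown or untested is made for them only; others in the source may bear on it.

Measured so far:
compound 1 `CC(=O)c1ccc(-c2cn3ccnc3c(-c3ccc4ncn(C5CCCCC5)c4c3)n2)cc1` — 18.8%
compound 2 `COc1ccccc1-c1cn2ccnc2c(-c2ccc3ncn(C4CCCCC4)c3c2)n1` — 33.6%

In a functional assay on HCT-15 cells (Homo sapiens) for inhibition, read by sulforhodamine B assay, with a stated time of 48 h, tested at 10 uM (on this read-out higher numbers stand for more inhibition at the one concentration tested (going by the name of the read-out) and lower numbers for less inhibition), compound 2 stands highest of the two numbers recorded; the nearest is compound 1, and the step of a number 14.8 percentage points higher from compound 1 to compound 2 (beyond the scatter) sets them apart beyond the scatter. Compound 3 `c1csc(-c2cn3ccnc3c(-c3ccc4ncn(C5CCCCC5)c4c3)n2)c1` is not yet measured. Its change from compound 2 is thiophen-2-yl in place of 2-methoxyphenyl on an aromatic carbon. For the measured compounds named here, the only measured step, a number 14.8 percentage points higher from compound 1 to compound 2 (beyond the scatter), also exchanges the group on this same aromatic carbon, and it was modest; it shows that this position can shift the read-out, but no measured pair pairs a thiophen-2-yl with a 2-methoxyphenyl, so the direction is open. A small loss against compound 2 is expected, within the scatter. For compound 3 the estimate in this assay is 26%, range 8% to 44%, meaning an expected step of a number 7.6 percentage points lower from compound 2 to compound 3 (within the scatter).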

Compound 3, a percentage reported as inhibition, at one concentration (the size of the read-out at that concentration, not a potency): 2.33%
Compound 3: the middle estimate sits 23.7 percentage points above what was measured; measured number outside the range, below it.
By their numbers in this assay, from the lowest: compound 3; then compound 1; then compound 2.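

Exchanging the aryl group on this aromatic carbon can do more than the first step suggested: in this assay, thiophen-2-yl in place of 2-methoxyphenyl gives a number 31.3 percentage points lower from compound 2 to compound 3 (beyond the scatter), and thiophen-2-yl in place of 4-acetylphenyl gives a number 16.5 percentage points lower from compound 1 to compound 3 (beyond the scatter). Among these three compounds, both substituted six-membered aryl groups therefore read above the five-membered thiophen-2-yl, and no compound shown goes against this order. No measurement here accounts for the loss.

Each step changes the ring and its substituent together, so the contribution of either one remains unresolved. An unsubstituted phenyl group would help separate them, while a 4-aminophenyl or 3-thienyl group would test how far the read-out at this position depends on the substituent or the point of ring attachment.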